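Benzyl in Place of Hydrogen on a Coumarin-Derived Chalcone

The compounds below may be only part of what the source reports. "The series", "measured", "known", "first", "only" and "open" are said of these compounds alone.

Measured compounds:
- compound 1 `COc1cc(/C=C/C(=O)c2cc3cc(O)ccc3oc2=O)cc(OC)c1OC` gives 10900 nM
- compound 2 `COC(=O)c1ccc(/C=C/C(=O)c2cc3ccc(O)cc3oc2=O)cc1` gives 5500 nM

Of the compounds shown here, two have been tested so far in a functional assay on MCF7 cells (Homo sapiens) for cytotoxicity, read by MTT assay, with a stated time of 72 h; on this read-out higher numbers stand for weaker inhibition and lower numbers for stronger inhibition. Compound 1 holds the highest of the two numbers; compound 2 sits lower by a gap that falls within the usual scatter, so the two values show no separation that can be read as a difference in potency. For the measured compounds named here, no step between measured compounds that differ in one place is available here.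

The next compound, compound 3 `COc1cc(/C=C/C(=O)c2cc3cc(OCc4ccccc4)ccc3oc2=O)cc(OC)c1OC`, follows from compound 1 by a single change: benzyl in place of hydrogen on an oxygen on an aromatic ring. Going by the values given here, with no comparable step among the measured compounds, there is nothing to lean on beyond the starting point and the nature of the change. The author expects the step in this assay to be modest, leaning toward stronger inhibition but not clearly beyond the scatter, so that a 1.4-fold lower number from compound 1 to compound 3 (0.13 log units; within the scatter) is the estimated shift. For compound 3 the estimated value is 8000 nM, with a range from 2500 nM to 25000 nM.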

Compound 3, half-maximal inhibitory concentration: 26500 nM
The estimate for compound 3 lay 3.3-fold (0.52 log units) below the measured number; the measured number lies above the stated range.
By their numbers in this assay, from the lowest: compounds 2 and 1 (each within the scatter of the next); then compound 3.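

In this assay, replacing hydrogen with benzyl on an oxygen on an aromatic ring, the change from hydroxy to benzyloxy, gives a 2.4-fold higher number from compound 1 to compound 3 (0.39 log units; beyond the scatter) and so moves toward weaker inhibition by more than the scatter. For the compounds shown here, this single pair is the first readable evidence on this position: on the core of compound 1, the added benzyl does not strengthen inhibition, and the free hydroxy gives the lower number of the two. Nothing measured here bears on why the number rises with this change.

The result rests on one pair and establishes no trend, leaving open how the number would respond to a smaller group on the same oxygen, such as methyl, or to a longer chain ending in an amine or a carboxylic acid. It also leaves open whether benzyl would produce a step of similar size and direction on the core of compound 2, or whether a benzyl ring carrying its own substituent, such as fluorine or methoxy, would give a different number from compound 3.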